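A methoxy for fluoro swap in a benzamide series

The source may report more compounds than this note shows. Statements on the series, on what has been measured and on what is new or still open speak of the compounds shown alone.

The three measured compounds share one core, a fluoro- and nitrile-bearing benzamide joined to a small aromatic amine. Compound 1 `Cn1ccc(NC(=O)c2cc(F)cc(C#N)c2)n1` carries a methylpyrazole amine, compound 2 `Cc1ccnc(NC(=O)c2cc(F)cc(C#N)c2)c1` a methylpyridine amine, and compound 3 `N#Cc1cc(F)cc(C(=O)Nc2ccccc2F)c1` a fluorophenyl amine. In an in vitro functional assay on HEK293-A cells for antagonist activity at metabotropic glutamate receptor 5 (Rattus norvegicus), read by calcium flux (a lower number here means a stronger inhibitor, a higher number a weaker inhibitor), compound 1 reaches only the limit > 10000 nM. Compound 2 likewise sits at the limit > 10000 nM in this assay. Compound 3 stands at the limit > 30000 nM in this assay. None of the three gives a number; the picture is the limit of > 10000 nM in this assay, at which 2 of the 3 values shown sit, and (the limit of > 30000 nM in this assay, at which 1 of the 3 values shown sits), with compound 3 at the higher of the two limits.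

Compound 4 `COc1ccccc1NC(=O)c1cc(F)cc(C#N)c1` is the next compound, not yet measured. It differs from compound 3 by methoxy in place of fluoro on an aromatic carbon. Among the compounds with values here, no measured pair shows a step of this kind, so nothing here says how large a change to expect. The expected step from compound 3 to compound 4 is an at least 1.2-fold lower number from compound 3 to compound 4 (0.07 log units; that floor lies within the scatter), which is taken as no movement beyond the scatter, since every measured compound stays at a limit. Compound 4 is therefore expected to give about 25000 nM in this assay, with a range from 5000 nM to 100000 nM, and most likely only another limit.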

Compound 4, half-maximal inhibitory concentration: > 30000 nM
Compound 4: a limit, no number; the forecaster's own chance of this, stated with the estimate: 75%; middle value at least 1.2-fold (0.07 log units) away from the limit.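

In this assay compound 4 gives > 30000 nM, which is a limit and not a number. Within the data shown here, compound 3 also stands at a limit, so no step between compound 3 and compound 4 can be read. The compounds shown leave open whether methoxy in place of fluoro changes inhibition at all; none of the four yields a number.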